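From 2-Methoxyphenyl to 3-Chloro-4-Fluorophenyl on the Amide Nitrogen

The compounds below may be only part of what the source reports. "The series", "measured", "known", "first", "only" and "open" are said of these compounds alone.

Of the compounds shown here, three have been tested in an ADME assay on HBZY-1 cells (Rattus norvegicus) for cytotoxicity, read by MTT assay, with a stated time of 2 h; on this read-out higher numbers stand for weaker inhibition and lower numbers for stronger inhibition: compound 1 (`COc1ccccc1NC(=O)/C=C/c1ccccc1C(F)(F)F`), compound 2 (`COc1ccccc1NC(=O)/C(C#N)=C/c1ccccc1C(F)(F)F`) and compound 3 (`COc1ccc(CNC(=O)/C(C#N)=C/c2ccccc2C(F)(F)F)cc1`). Compound 1 reads > 200000 nM, which is a limit of the assay and not a number. Compound 2 reads > 200000 nM, also a limit. Compound 3 reads > 200000 nM, again a limit. Compound 2 therefore stands at the limit of > 200000 nM in this assay, at which 3 of the 3 values shown sit. Compound 4 (`N#C/C(=C\c1ccccc1C(F)(F)F)C(=O)Nc1ccc(F)c(Cl)c1`) has 3-chloro-4-fluorophenyl in place of 2-methoxyphenyl on an amide-type nitrogen. Among the measured compounds shown here, no measured pair shows what such a swap does in this assay. The expected step of an at least 1.2-fold lower number from compound 2 to compound 4 (0.09 log units; that floor lies within the scatter) stays within the usual scatter. Compound 4 is estimated at 160000 nM, with an expected range of 60000 nM to 400000 nM.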

Compound 4, half-maximal inhibitory concentration: > 200000 nM
Compound 4 gave a limit, no number; the forecaster's own chance of this, stated with the estimate: 60%; at least 1.2-fold (0.09 log units) between middle value and limit.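

In this assay, among the compounds shown here, compound 2 and compound 4 both give only a limit of the assay, not a number, and no step between them can be read. What 3-chloro-4-fluorophenyl in place of 2-methoxyphenyl does to the read-out, and at what concentration any of these compounds would inhibit, stays open.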